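The source may report more compounds than this note shows. Statements on the series, on what has been measured and on what is new or still open speak of the compounds shown alone.

Series notes. Compound 1 `O=C(Nc1cccc(/C=C/C(=O)c2nc3ccccc3[nH]2)c1)c1ccc(Cl)cc1` is measured in a functional assay on HCT-116 cells (Homo sapiens) for antiproliferative activity, read by MTT assay, with a stated time of 48 h (on this read-out lower numbers stand for stronger inhibition and higher numbers for weaker inhibition), at 2270 nM. For the measured compounds named here, its sole measured neighbour, compound 2 `O=C(Nc1cccc(/C=C/C(=O)c2nc3ccccc3[nH]2)c1)c1cccc(Br)c1`, gives 1560 nM in this assay, and the step of a 1.5-fold lower number from compound 1 to compound 2 (0.16 log units; within the scatter) does not separate the two. Compound 3 `O=C(/C=C/c1cccc(NS(=O)(=O)c2ccccc2Cl)c1)c1nc2ccccc2[nH]1` is not yet measured; it differs from compound 1 as follows: (2-chlorophenyl)sulfonyl in place of (4-chlorophenyl)carbonyl on a nitrogen on an aromatic ring. Going by the values given here, the single measured step moves only a halogen on the ring attached to the carbonyl, so no step here tests the exchange of that carbonyl-bearing group for a sulfonyl-bearing one; the expectation is therefore no step beyond the scatter, with a 1.0-fold lower number from compound 1 to compound 3 (0.01 log units; within the scatter) as the expected step. For compound 3 the estimate in this assay is 2200 nM, expected range 700 nM to 7000 nM.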

Compound 3, half-maximal inhibitory concentration: 987 nM
Estimate against measurement, compound 3: 2.2-fold (0.35 log units) above; the range from low to high includes it.
By their numbers in this assay, from the lowest: compounds 3, 2 and 1 (each within the scatter of the next, the first and the last beyond it).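

In this assay, for the compounds shown here, the exchange of (4-chlorophenyl)carbonyl for (2-chlorophenyl)sulfonyl on a nitrogen on an aromatic ring gives a 2.3-fold lower number from compound 1 to compound 3 (0.36 log units; beyond the scatter) and is the first step beyond the scatter, so this position accepts a sulfonyl-bearing group with no loss. Measured against the bromine-bearing amide, the exchange gives a 1.6-fold lower number from compound 2 to compound 3 (0.20 log units; within the scatter) and does not separate the two compounds. No evidence in hand bears on the cause of either step. Going by these compounds, compound 3 changes the sulfonyl link and the chlorine's place together, so the share of each stays open. On these data alone, how an amine or a longer carbon chain would read in place of the chlorophenyl ring also remains open.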